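Replacing diethylamino with 4-methylpiperazin-1-yl in compound 3

The source may report more compounds than this note shows. Statements on the series, on what has been measured and on what is new or still open speak of the compounds shown alone.

Three compounds share a common core and were measured in an assay on HEK293 cells for displacement of a labelled ligand from growth hormone secretagogue receptor type 1 (Homo sapiens), with a stated time of 60 min; a lower number here means a stronger inhibitor, a higher number a weaker inhibitor. Compound 1, `CN1CCN(CCCS(=O)(=O)c2ccc3nc(NC(=O)NC(=O)c4cc(C5CC5)ccc4Cl)sc3c2)CC1`, gives 0.33 nM. Compound 2, `COc1cc(Cl)c(C(=O)NC(=O)Nc2nc3ccc(S(=O)(=O)CCCN4CCN(C)CC4)cc3s2)cc1-n1cccn1`, gives 0.62 nM. Compound 3, `CCN(CC)CCCS(=O)(=O)c1ccc2nc(NC(=O)NC(=O)c3cc(-n4cccn4)ccc3Cl)sc2c1`, gives 3.9 nM, the highest of the three numbers; the gap to compound 2 and the larger gap to compound 1 both lie beyond the scatter of this assay. Compounds 1 and 2 both carry the 4-methylpiperazin-1-yl group on the chain, whereas compound 3 carries diethylamino there.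

Compound 4, `CN1CCN(CCCS(=O)(=O)c2ccc3nc(NC(=O)NC(=O)c4cc(-n5cccn5)ccc4Cl)sc3c2)CC1`, has not been measured. It differs from compound 3 in one place: 4-methylpiperazin-1-yl in place of diethylamino on a saturated chain carbon, three bonds along the chain from a sulfonyl sulfur. Among the compounds with values here, no measured pair isolates this change, so its size is an expectation only. Compound 1, which bears the entering group, gives 0.33 nM, and compound 2, which also bears it, gives 0.62 nM. On that basis a step towards a lower number is expected, of roughly a 6.5-fold lower number from compound 3 to compound 4 (0.81 log units; beyond the scatter) in this assay. Compound 4 is therefore estimated at 0.6 nM, with a range from 0.2 nM to 2 nM.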

Compound 4, half-maximal inhibitory concentration in the growth hormone secretagogue receptor type 1 assay: 0.67 nM
Estimate against measurement, compound 4: 1.1-fold (0.05 log units) below, within the range that was stated.
By their numbers in the growth hormone secretagogue receptor type 1 assay, from the lowest: compounds 1, 2 and 4 (each within the scatter of the next, the first and the last beyond it); then compound 3.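

In the growth hormone secretagogue receptor type 1 assay, the exchange on this saturated chain carbon now has a measured size of its own, a 5.8-fold lower number from compound 3 to compound 4 (0.76 log units; beyond the scatter), with the rest of the molecule unchanged. In a physicochemical assay for lipophilicity (on this read-out lower numbers stand for lower lipophilicity and higher numbers for higher lipophilicity), compound 3 gives 2.1 and compound 4 gives 2, two values within the scatter of each other, so the step in binding comes without a separable shift on that read-out. Compound 4 also links the two 4-methylpiperazin-1-yl compounds in the growth hormone secretagogue receptor type 1 assay through single changes on an aromatic carbon: hydrogen in place of methoxy gives a 1.1-fold higher number from compound 2 to compound 4 (0.03 log units; within the scatter), and 1H-pyrazol-1-yl in place of cyclopropyl gives a 2.0-fold higher number from compound 1 to compound 4 (0.31 log units; beyond the scatter).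

Nothing shown explains why the exchange on the chain moves the binding number. From the compounds shown here alone, whether a morpholin-4-yl or piperidin-1-yl group, or a longer chain, would hold the number of compound 4 remains open.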